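The compounds below may be only part of what the source reports. "The series", "measured", "known", "first", "only" and "open" are said of these compounds alone.

Compound 1 `Cc1ccc2nc(Cl)c(Cn3cc(Cn4cnn(-c5ccccc5)c4=O)nn3)cc2c1`: 478 ug/mL
Compound 2 `O=c1n(Cc2cn(Cc3cc4ccccc4nc3Cl)nn2)cnn1-c1ccccc1`: 655 ug/mL
Compound 3 `COc1ccc(-n2ncn(Cc3cn(Cc4cc5cc(C)ccc5nc4Cl)nn3)c2=O)cc1`: 615 ug/mL

In an ADME assay on HEK293 cells (Homo sapiens) for cytotoxicity, read by MTT assay (on this read-out lower numbers stand for stronger inhibition and higher numbers for weaker inhibition), compound 1 gives 478 ug/mL. Compound 2 differs from compound 1 by hydrogen in place of methyl on an aromatic carbon, and the step is a 1.4-fold higher number from compound 1 to compound 2 (0.14 log units; within the scatter). Compound 3 differs from compound 1 by methoxy in place of hydrogen on an aromatic carbon, and that step is a 1.3-fold higher number from compound 1 to compound 3 (0.11 log units; within the scatter). All three numbers lie within the scatter of one another, so none of them can be set apart from the others.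

Compound 4 `COc1ccc2cc(Cn3cc(Cn4cnn(-c5ccccc5)c4=O)nn3)c(Cl)nc2c1` has not yet been measured in this assay. It differs from compound 2 by methoxy in place of hydrogen on an aromatic carbon. Among the measured compounds shown here, this is the same kind of change as the one from compound 1 to compound 3, but not the same: there the entering group sat on a six-membered aromatic ring of carbon only, para to a large group, whereas here it sits on such a ring that is part of a fused or bridged system of two rings, meta to a fused ring and para to a fused ring. Because the earlier step was a 1.3-fold higher number from compound 1 to compound 3 (0.11 log units; within the scatter), the step to compound 4 is expected to be a 1.1-fold higher number from compound 2 to compound 4 (0.04 log units; within the scatter), again within the scatter. Compound 4 is estimated at 720 ug/mL, with a likely range from 450 ug/mL to 1150 ug/mL.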

Compound 4, half-maximal inhibitory concentration: 1010 ug/mL
Compound 4: middle estimate off by 1.4-fold (0.15 log units), on the low side; low and high end bracket the measured number.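

In this assay, methoxy in place of hydrogen on an aromatic carbon gives a 1.5-fold higher number from compound 2 to compound 4 (0.19 log units; within the scatter), a step that, like the earlier one, stays within the usual scatter of repeated measurements. Set beside the earlier step, it shows no difference between the two cores: the same change on two cores in this assay, a 1.3-fold higher number (0.11 log units; within the scatter) from compound 1 to compound 3 and a 1.5-fold higher number (0.19 log units; within the scatter) from compound 2 to compound 4, 1.2-fold (0.08 log units) apart, within the scatter of two such steps. Among the compounds shown here, this agreement shows only that the change stayed within the scatter on both cores, with methoxy entering on a plain six-membered aromatic ring of carbon in one case and on such a ring within a fused or bridged system of two rings in the other; it does not show that methoxy has a real effect of a shared size, or that the change would behave alike on any other core.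

The compounds shown leave open whether a group such as an amine, a carboxylic acid or a longer chain at these aromatic carbons would give a step beyond the scatter. They also leave open how methoxy would behave at other places on these rings.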